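A Pyrazole Acid Replaces the Carboxyphenyl Group

The source may report more compounds than this note shows. Statements on the series, on what has been measured and on what is new or still open speak of the compounds shown alone.

Measured compounds:
compound 1 `O=C(O)c1ccc([C@H]2C[C@](O)(c3ccc(OCc4c(-c5c(Cl)cccc5Cl)noc4C4CC4)cc3Cl)C2)cc1`: 1.1 h
compound 2 `O=C(O)c1cccc(C2CC2c2ccc(OCc3c(-c4c(Cl)cccc4Cl)noc3C3CC3)cc2Cl)c1`: 1 h

In an ADME assay on the whole organism (strain C57BL/6J) for metabolic stability, with Mus musculus as the target (on this read-out lower numbers stand for a shorter-lived compound and higher numbers for a longer-lived compound), compound 1 gives 1.1 h, the higher of the two numbers, while compound 2 gives 1 h; the gap lies within the scatter, so the two cannot be told apart on this read-out. Compound 3 `CC(C)n1nc(C(=O)O)cc1[C@H]1C[C@](O)(c2ccc(OCc3c(-c4c(Cl)cccc4Cl)noc3C3CC3)cc2Cl)C1` differs from compound 1 in one place: 3-carboxy-1-isopropyl-1H-pyrazol-5-yl in place of 4-carboxyphenyl on a saturated ring carbon. Among the compounds with values here, no measured pair shows this change, so the step from compound 1 to compound 3 is expected to be small, a 1.2-fold higher number from compound 1 to compound 3 (0.07 log units; within the scatter), not beyond the scatter. Compound 3 is therefore estimated at 1.3 h, within a range from 0.6 h to 2.8 h.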

Compound 3, half-life: 0.6 h
Beside the measured number, compound 3's estimate is 2.2-fold (0.34 log units) above it; the measured number falls inside the stated range.
By their numbers in this assay, from the lowest: compounds 3, 2 and 1 (each within the scatter of the next).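

On a saturated ring carbon of the four-membered ring, 3-carboxy-1-isopropyl-1H-pyrazol-5-yl can stand in place of 4-carboxyphenyl with a 1.8-fold lower number from compound 1 to compound 3 (0.26 log units; within the scatter) in this assay. The first replacement shown at this position therefore leaves the two compounds indistinguishable on this read-out, although the incoming group has a different aromatic ring and carries an isopropyl group. Nothing available bears on a cause for this result. Still open, going by these compounds, is how an amide in place of the carboxylic acid, or a methyl or cyclopropyl group in place of the isopropyl, would read in this assay.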